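Swapping an aryl alkyne for a plain alkyl alkyne

A few compounds are considered here, and "the series" means these few. Any claim that something is new, unique, unknown or untested is made for them only; others in the source may bear on it.

Compound 3 `CCCCCc1ccc(C#Cc2cn(CCC(COC(C)=O)COC(C)=O)c(=O)n(C(=O)c3ccccc3)c2=O)cc1` is measured in a functional assay on HeLa cells (Homo sapiens) for antiproliferative activity, read by MTT assay, with a stated time of 72 h (a lower number here means a stronger inhibitor, a higher number a weaker inhibitor), where compound 3 gives 79100 nM. For the measured compounds named here, that is the highest of the three numbers known. Its neighbour compound 2 `CC(=O)OCC(CCn1cc(C#Cc2cc(F)cc(F)c2)c(=O)n(C(=O)c2ccccc2)c1=O)COC(C)=O` gives 64500 nM, and the step of a 1.2-fold higher number from compound 2 to compound 3 (0.09 log units; within the scatter) stays inside the scatter. The furthest is compound 1 `O=c1[nH]c(=O)n(CCC(CO)CO)cc1-c1cccs1`, which gives 7800 nM; that gap is beyond the scatter, but compound 1 differs from compound 3 in several places at once, so no single change can be read from it.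

Compound 4 `CCCCCC#Cc1cn(CCC(COC(C)=O)COC(C)=O)c(=O)n(C(=O)c2ccccc2)c1=O` differs from compound 3 in one place: pentyl in place of 4-pentylphenyl on a triple-bonded carbon. Going by the values given here, the only measured step at this position is a 1.2-fold higher number from compound 2 to compound 3 (0.09 log units; within the scatter), which exchanged one aromatic ring for another and changed little. Among the compounds with values here, no measured step exchanges a ring for a chain at this position, so the expectation rests on the modest size of that one step. The estimated step of a 1.1-fold higher number from compound 3 to compound 4 (0.06 log units; within the scatter) is therefore expected to stay within the scatter. For compound 4 the expected value is 90000 nM, in a range from 35000 nM to 250000 nM.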

Compound 4, half-maximal inhibitory concentration: 53700 nM
Compound 4: the middle estimate sits 1.7-fold (0.22 log units) above what was measured; low and high end bracket the measured number.
By their numbers in this assay, from the lowest: compound 1; then compounds 4, 2 and 3 (each within the scatter of the next).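

Replacing the ring on the triple-bonded carbon with a plain pentyl chain gives a 1.5-fold lower number from compound 3 to compound 4 (0.17 log units; within the scatter) in this assay, and the same exchange from the other ring compound gives a 1.2-fold lower number from compound 2 to compound 4 (0.08 log units; within the scatter) in the same assay. The earlier step only traded one aromatic ring for another, whereas these show that, among the compounds here, a carbon chain with no ring gives a number that cannot be told apart from either ring compound. No measurement is available to explain this result.

On these data alone, whether an amine, a carboxylic acid or a longer chain on the triple-bonded carbon would also leave the number within the scatter remains open. Compound 1 differs from these compounds in several places, so its gap to them cannot be assigned to any single change.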